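Nitro for chloro on the anilide ring of the series

The compounds below may be only part of what the source reports. "The series", "measured", "known", "first", "only" and "open" are said of these compounds alone.

Three analogues share one core and differ only in the chlorine position on the anilide ring. Compound 1 `O=C(CSc1nc(Nc2ccccc2)c2ccccc2n1)Nc1ccccc1Cl` gives 14600 nM in a functional assay on PC-3 cells (Homo sapiens) for inhibition, read by MTT assay, with a stated time of 72 h; on this read-out higher numbers stand for weaker inhibition and lower numbers for stronger inhibition. Compound 2 `O=C(CSc1nc(Nc2ccccc2)c2ccccc2n1)Nc1cccc(Cl)c1` gives 12600 nM in this assay, and compound 3 `O=C(CSc1nc(Nc2ccccc2)c2ccccc2n1)Nc1ccc(Cl)cc1` gives 12900 nM in this assay. The steps are flat: a 1.2-fold lower number from compound 1 to compound 2 (0.06 log units; within the scatter), a 1.1-fold lower number from compound 1 to compound 3 (0.05 log units; within the scatter) and a 1.0-fold higher number from compound 2 to compound 3 (0.01 log units; within the scatter). Compound 3 sits second highest of the three numbers, and none of them is separated from another beyond the scatter, so no ranking can be read from this set.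

Compound 4 `O=C(CSc1nc(Nc2ccccc2)c2ccccc2n1)Nc1ccc([N+](=O)[O-])cc1` is next. The change from compound 3 is nitro in place of chloro on an aromatic carbon, para to a large group. Within the data shown here, no measured step swaps the halogen for another group; the three steps only move chlorine around the ring, and all three stay within the scatter. They bear on the new step only indirectly, by showing that this ring tolerates a substituent change without a measurable shift in this assay. The expected step is therefore a 1.1-fold lower number from compound 3 to compound 4 (0.03 log units; within the scatter), that is, nothing beyond the scatter. Compound 4 is estimated at 12000 nM in this assay, with a range from 5000 nM to 30000 nM.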

Compound 4, half-maximal inhibitory concentration: 25000 nM
Estimate against measurement, compound 4: 2.1-fold (0.32 log units) below; low and high end bracket the measured number.
By their numbers in this assay, from the lowest: compounds 2, 3, 1 and 4 (each within the scatter of the next).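

Among these compounds, compound 4 is the first in this set to carry something other than chlorine on the anilide ring, and the swap of chloro for nitro, para to a large group, reads as a 1.9-fold higher number from compound 3 to compound 4 (0.29 log units; within the scatter) in this assay on this ring. Against the other two chloro analogues the readings are a 2.0-fold higher number from compound 2 to compound 4 (0.30 log units; within the scatter) and a 1.7-fold higher number from compound 1 to compound 4 (0.23 log units; within the scatter) in the same assay series, so the position takes nitro, with 3 heavy atoms and 2 hydrogen-bond acceptors, in place of a single chlorine without a step beyond the scatter, and the four compounds still give no ranking. No measurement available here bears on why these numbers fall as they do.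

As far as these compounds go, whether an amine, a carboxylic acid or a methoxy group on this same aromatic carbon would move the number beyond the scatter stays open. Also open, from the compounds shown here alone, is whether nitro at the other two ring places held by chlorine in compound 1 and compound 2 would read the same, and whether any of these numbers would hold on cells other than those of this single assay.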